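The compounds below may be only part of what the source reports. "The series", "measured", "known", "first", "only" and "open" are said of these compounds alone.

Compound 1 `Cc1oc(-c2c(F)cccc2F)nc1CN1CCC(C(=O)NCCCN2C[C@H](C)C[C@H](C)C2)CC1`: > 72 ug/mL
Compound 2 `Cc1cccc(Cl)c1-c1nc(CN2CCC(C(=O)NCCCN3CCC(C(C)C)CC3)CC2)c(C)o1`: > 76 ug/mL

In a physicochemical assay for solubility, in phosphate buffer, measured as kinetic solubility, at pH 7.4 (a lower number here means a less soluble compound, a higher number a more soluble compound), compound 1 gives > 72 ug/mL, which is a limit of the assay rather than a number. Compound 2 also sits at a limit, > 76 ug/mL. Both values shown are such limits, as the limit of > 72 ug/mL in this assay, at which 1 of the 2 values shown sits, and the limit of > 76 ug/mL in this assay, at which 1 of the 2 values shown sits, record. Compound 3 `COc1cccc(C)c1-c1nc(CN2CCC(C(=O)NCCCN3C[C@H](C)C[C@H](C)C3)CC2)c(C)o1` has not yet been measured. It differs from compound 1 in one place: 2-methoxy-6-methylphenyl in place of 2,6-difluorophenyl on an aromatic carbon. Going by the values given here, no step between measured compounds is available, so the effect of this change cannot be read from the data. The step that the limit leaves unreadable from compound 1 to compound 3 is expected to be none beyond the scatter. Compound 3 is expected to give about 75 ug/mL, within 35 ug/mL to 160 ug/mL, most likely again reported only as a limit.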

Compound 3, solubility: > 73 ug/mL
Compound 3: only a limit was reported (the forecaster's own chance of this, stated with the estimate: 70%); the middle value lies beyond the limit too.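

Going by these compounds alone, compound 1 and compound 3 both stop at a limit in this assay, so no step between them can be read. Still open, on these data alone, is whether 2-methoxy-6-methylphenyl in place of 2,6-difluorophenyl changes solubility at all.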